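A few compounds are considered here, and "the series" means these few. Any claim that something is new, unique, unknown or untested is made for them only; others in the source may bear on it.

Measured compounds:
compound 1, `C=CC(=O)N1C(=O)CC(c2ccc(Br)cc2)Sc2ccccc21`, in a functional assay on HL-60 cells (Homo sapiens) for cytotoxicity, read by CCK-8 assay, with a stated time of 24 h (on this read-out higher numbers stand for weaker inhibition and lower numbers for stronger inhibition), gives 126000 nM
compound 2, `C=CC(=O)N1C(=O)CCSc2ccccc21`, in this assay gives 44800 nM

Among the compounds with values here, compound 1 holds the highest of the two numbers in this assay; its only neighbour on the numbers is compound 2, reached by hydrogen in place of 4-bromophenyl on a saturated ring carbon, a change that gave a 2.8-fold lower number from compound 1 to compound 2 (0.45 log units; beyond the scatter). Compound 3, `C=CC(=O)N1C(=O)CC(c2ccc(C(=O)OC)cc2)Sc2ccccc21`, is not yet measured. It differs from compound 1 in one place: methoxycarbonyl in place of bromo on an aromatic carbon. Within the data shown here, no measured step touches the bromo group itself. Among the measured compounds shown here, the single step known in this assay, a 2.8-fold lower number from compound 1 to compound 2 (0.45 log units; beyond the scatter), removes the whole 4-bromophenyl and therefore gives no direct guide to exchanging one substituent on that ring for another; the ring itself is kept in compound 3. For the measured compounds named here, with no closer precedent, no step beyond the scatter is expected from compound 1 to compound 3, and the range is kept wide enough to cover a modest movement in either direction. Compound 3 is accordingly expected to give about 100000 nM in this assay, with a range from 35000 nM to 300000 nM. The expected step is a 1.3-fold lower number from compound 1 to compound 3 (0.10 log units; within the scatter).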

Compound 3, half-maximal inhibitory concentration: 102000 nM
The estimate for compound 3 lay 1.0-fold (0.01 log units) below the measured number; the range from low to high includes it.
By their numbers in this assay, from the lowest: compound 2; then compounds 3 and 1 (each within the scatter of the next).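

In this assay, within the data shown here, the step of a 1.2-fold lower number from compound 1 to compound 3 (0.09 log units; within the scatter) is the first measured exchange of a substituent on the aromatic ring, with the ring itself kept: methoxycarbonyl, with 4 heavy atoms and 2 hydrogen-bond acceptors, enters where bromo, with 1 heavy atom and 0 hydrogen-bond acceptors, leaves. On this aromatic carbon, para to a large group, the two substituents are not told apart by this read-out, while the step of a 2.8-fold lower number from compound 1 to compound 2 (0.45 log units; beyond the scatter), which removes the whole 4-bromophenyl, remains the only one in the set beyond the scatter. No supporting measurement is available to account for either result.

From the compounds shown here alone, whether the same holds for other groups on this aromatic carbon, such as an amine or a carboxylic acid, remains open. Also open, going by these compounds, is how an unsubstituted phenyl ring at the saturated ring carbon would compare, which would separate the contribution of the ring from that of its substituent.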